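Swapping a Phenylethyl for a Pentyl Chain

A few compounds are considered here, and "the series" means these few. Any claim that something is new, unique, unknown or untested is made for them only; others in the source may bear on it.

Measured so far:
- Compound 1 `N/C(=N\C(=O)NCc1ccccc1)NC1CCc2nc(N)sc2C1`: 0.31
- Compound 2 `Cc1nc(N)sc1CCCN/C(N)=N/C(=O)N[C@@H](C)c1ccccc1`: 0.46
- Compound 3 `N/C(=N\C(=O)NC1CCCCC1)Nc1cccc(-c2csc(N)n2)c1`: "not determined" (no result reported)

In a functional assay on HEK293T cells for agonist activity at histamine H2 receptor (Homo sapiens), read by beta-arrestin recruitment (a higher number here means a larger maximal response, a lower number a smaller maximal response), compound 2 gives 0.46, the highest of the two numbers recorded. Compound 1 gives 0.31, a gap that lies beyond the usual scatter of repeated measurements, so compound 2 reaches a clearly larger maximal response than compound 1. Compound 3 was carried through the same assay, but its entry reads "not determined" (no result reported), so it cannot be placed against the other two.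

Compound 4 `CCCCCNC(=O)/N=C(\N)NCCCc1sc(N)nc1C` keeps the core of compound 2 and changes a single group. The difference is pentyl in place of 1-phenylethyl on an amide-type nitrogen.

Going by the values given here, no measured pair in this set differs by exactly this kind of exchange, so there is no measured step to lean on. Given that compound 2 stands at 0.46 and that the exchange removes one six-membered aromatic ring of carbon only in favour of a plain pentyl chain, a modest drop in maximal response is expected, though it may well stay within the scatter. The step from compound 2 to compound 4 is estimated at a number 0.080 lower from compound 2 to compound 4 (within the scatter). Compound 4 is therefore expected to give about 0.38 in this assay, with a plausible range from 0.2 to 0.6.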

Compound 4, intrinsic activity: the largest response reached, as a fraction of the reference agonist's: 0.15
Compound 4: the middle estimate sits 0.23 above what was measured; the whole stated range lies above it.
By their numbers in this assay, from the lowest: compound 4; then compound 1; then compound 2.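

In this assay, going by these compounds alone, the exchange of 1-phenylethyl for pentyl on the amide-type nitrogen gives the first single-place comparison in this set, and the reading comes out a number 0.31 lower from compound 2 to compound 4 (beyond the scatter). This shows that the maximal response depends strongly on the group at this position on the core of compound 2, and that a plain pentyl chain cannot stand in for 1-phenylethyl here. Several things change together in this one step, since the group that leaves has 8 heavy atoms, a six-membered aromatic ring of carbon only and a defined stereocentre, while pentyl has 5 heavy atoms and no ring, and nothing available explains the drop.

The compounds shown leave open which of these differences matters most, the ring, the branching carbon with its stereocentre, or the size of the group. On the same core, a 2-phenylethyl group would keep the ring without the branch, while a cyclopentyl ring would keep a ring with no aromatic carbon, so each would test a part of the question.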